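From 2-Chlorophenyl to 4-Bromophenyl: A Small Step Expected

The source may report more compounds than this note shows. Statements on the series, on what has been measured and on what is new or still open speak of the compounds shown alone.

Of the compounds shown here, three with a shared core have been measured in a functional assay on SGC-7901 cells (Homo sapiens) for inhibition, read by MTT assay, with a stated time of 24 h; a lower number here means a stronger inhibitor, a higher number a weaker inhibitor. Compound 1 `CC1(C)[C@H]2CC[C@]1(C)N(Cc1cn(-c3ccccc3Br)nn1)C(=O)C2` gives 500 nM, compound 2 `CC1(C)[C@H]2CC[C@]1(C)N(Cc1cn(-c3cccc(C#N)c3)nn1)C(=O)C2` gives 250 nM, and compound 3 `CC1(C)[C@H]2CC[C@]1(C)N(Cc1cn(-c3ccccc3Cl)nn1)C(=O)C2` gives 220 nM. Compound 3 thus stands level with compound 2 within the scatter and separates, modestly, only from compound 1.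

The next compound, compound 4 `CC1(C)[C@H]2CC[C@]1(C)N(Cc1cn(-c3ccc(Br)cc3)nn1)C(=O)C2`, carries 4-bromophenyl in place of 2-chlorophenyl on an aromatic nitrogen. The closest evidence is the exchange of bromo for chloro, a 2.3-fold lower number from compound 1 to compound 3 (0.36 log units; beyond the scatter), which suggests that a return to bromo could raise the number. The other two steps, a 2.0-fold lower number from compound 1 to compound 2 (0.30 log units; within the scatter) and a 1.1-fold lower number from compound 2 to compound 3 (0.06 log units; within the scatter), show that replacing the group on this nitrogen has so far moved little. Among the compounds with values here, no measured compound carries 4-bromophenyl, so that placement remains untested.

A small rise is therefore expected, an estimated 1.6-fold higher number from compound 3 to compound 4 (0.20 log units; within the scatter), which would stay within the scatter. For compound 4 the expected value is 350 nM, with an estimated range of 120 nM to 1000 nM.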

Compound 4, half-maximal inhibitory concentration: 450 nM
Beside the measured number, compound 4's estimate is 1.3-fold (0.11 log units) below it, within the range that was stated.
By their numbers in this assay, from the lowest: compounds 3, 2, 4 and 1 (each within the scatter of the next, the first and the last beyond it).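

In this assay, the exchange of 2-chlorophenyl for 4-bromophenyl on the aromatic nitrogen is a modest step beyond the scatter (a 2.0-fold higher number from compound 3 to compound 4 (0.31 log units; beyond the scatter)), so this position does distinguish between two halogen-bearing phenyl groups. The two bromophenyl placements cannot be told apart, however (a 1.1-fold lower number from compound 1 to compound 4 (0.05 log units; within the scatter)), and compound 4 also stays within the scatter of the 3-cyanophenyl compound (a 1.8-fold higher number from compound 2 to compound 4 (0.26 log units; within the scatter)), so only compound 3 separates from the two bromo compounds. No measured information on these compounds bears on this result, and the reason for it stays unknown.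

Still open, from the compounds shown here alone, is whether 4-chlorophenyl would stand with compound 3 or with compound 4, which would separate the choice of halogen from its placement. Also open, going by these compounds, is how the number would respond to an amine or a carboxylic acid on the phenyl ring.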